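Cytotoxicity limits in a cyclic sulfonylurea benzyl series

The source may hold more compounds than are shown below. What is called first, only, known or untested is meant among the compounds shown, and "the series" means these compounds.

Compound 1 `O=C1c2ccccc2N(Cc2ccccc2Cl)S(=O)(=O)N1COCc1ccccc1` is assessed in a functional assay on HEL cells (Homo sapiens) for inhibition; a lower number here means that less compound is tolerated, a higher number that more compound is tolerated. In this assay compound 1 gives only a limit, > 50000 nM. Compound 2 `O=C1c2ccccc2N(Cc2ccccc2)S(=O)(=O)N1COCc1ccccc1` differs from compound 1 by hydrogen in place of chloro on an aromatic carbon. In this assay compound 2 likewise gives only a limit, > 98000 nM. Because both values sit at limits the limit of > 50000 nM in this assay, at which 1 of the 3 values shown sits, and (the limit of > 98000 nM in this assay, at which 1 of the 3 values shown sits), the step that the two limits leave unreadable from compound 1 to compound 2 cannot be read. Compound 3 `O=C1c2ccccc2N(Cc2ccc(Cl)cc2)S(=O)(=O)N1Cc1ccc(Cl)cc1` carries a core whose difference from that of compound 1 is not broken down here. In this assay compound 3 gives only a limit, > 200000 nM. Compound 4 `O=C1c2ccccc2N(Cc2ccc(Cl)cc2)S(=O)(=O)N1Cc1ccccc1` differs from compound 3 by hydrogen in place of chloro on an aromatic carbon. This is the same kind of change as from compound 1 to compound 2, though the place differs: there it is ortho to a large group, here para to a large group. For the measured compounds named here, for compound 4 the step of a number no higher from compound 3 to compound 4 (the limit leaves the size open) is expected to be small, because compound 3 sits at the limit of > 200000 nM in this assay, at which 1 of the 3 values shown sits, and no measured step of this change is readable. Compound 4 is estimated at 200000 nM, between 60000 nM and 600000 nM, most likely again reported only as a limit.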

Compound 4, half-maximal cytotoxic concentration: > 200000 nM
Compound 4 ended at the assay's limit (the forecaster's own chance of this, stated with the estimate: 85%); the middle value lies on the limit itself.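

Compound 3 and compound 4 both sit at the same limit in this assay, so the step between them cannot be read: the limit of > 200000 nM in this assay, at which 2 of the 4 values shown sit.

The compounds shown leave open whether hydrogen in place of chloro on an aromatic carbon changes the tolerated concentration at all, in either pair, compound 1 with compound 2 or compound 3 with compound 4.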